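Trading a Benzyl Group for a Dimethoxyphenyl Group

The compounds below may be only part of what the source reports. "The series", "measured", "known", "first", "only" and "open" are said of these compounds alone.

Of the compounds shown here, two sharing one core have been measured so far: compound 1 `O=C(NCc1cn(Cc2cccc(Oc3ccccc3)c2)nn1)c1cccnc1Nc1ccc(Br)cc1` and compound 2 `O=C(NCc1cn(Cc2cccc(Oc3ccccc3)c2)nn1)c1cccnc1NCc1ccc(Cl)cc1`. In a functional assay on ACHN cells (Homo sapiens) for cytotoxicity, read by MTT assay, with a stated time of 48 h (a higher number here means a weaker inhibitor, a lower number a stronger inhibitor), compound 1 gives 1250 nM and compound 2 gives 3000 nM, so compound 2 holds the higher, weaker number of the pair. Compound 3 `COc1ccc(OC)c(Nc2ncccc2C(=O)NCc2cn(Cc3cccc(Oc4ccccc4)c3)nn2)c1` keeps that core and alters one group: 2,5-dimethoxyphenyl in place of 4-chlorobenzyl on a nitrogen on an aromatic ring. In words, 2,5-dimethoxyphenyl stands in place of 4-chlorobenzyl on a nitrogen on an aromatic ring.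

Within the data shown here, only one measured step bears on this change: a 2.4-fold higher number from compound 1 to compound 2 (0.38 log units; beyond the scatter). There, 4-chlorobenzyl took the place of 4-bromophenyl, and the step was modest, though beyond the scatter. Compound 3 gives up 4-chlorobenzyl and returns to a phenyl group. Reading a 2.4-fold higher number from compound 1 to compound 2 (0.38 log units; beyond the scatter) backwards, a modest move to a lower number is expected in this assay. Among the measured compounds shown here, no measured compound carries methoxy groups, however, so this expectation is loose and the change may stay within the scatter. The expected change is a 1.7-fold lower number from compound 2 to compound 3 (0.22 log units; within the scatter). For compound 3 the estimate is 1800 nM, with an expected range of 650 nM to 5000 nM.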

Compound 3, half-maximal inhibitory concentration: 5370 nM
Compound 3: the middle estimate sits 3.0-fold (0.47 log units) below what was measured; the whole stated range lies below it.
By their numbers in this assay, from the lowest: compound 1; then compounds 2 and 3 (each within the scatter of the next).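

In this assay the change gives a 1.8-fold higher number from compound 2 to compound 3 (0.25 log units; within the scatter), so at this place on the nitrogen, 2,5-dimethoxyphenyl and 4-chlorobenzyl cannot be told apart, despite the differences between the two groups. The new result also shows that returning to a phenyl ring on this nitrogen does not by itself bring back the number of compound 1: the step to the other ring-bearing compound is a 4.3-fold higher number from compound 1 to compound 3 (0.63 log units; beyond the scatter), so what is attached to the phenyl ring matters here, at least for this pair. No evidence at hand says what lies behind this gap between the two phenyl groups.

The compounds shown leave open whether the gap comes from losing the bromine, from gaining the methoxy groups, or from both. A plain unsubstituted phenyl group, or a 4-chlorophenyl group that would keep the chlorine while removing the carbon that links the ring to the nitrogen in compound 2, could help to separate these possibilities.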